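Replacing cyclohexyl with 4-fluorophenyl in compound 1

This account rests on a few compounds, and the source may have more. Where it says the series, first, only, none or still open, it means among the compounds named here.

Measured in a functional assay on KB-V1 cells (Homo sapiens) for cytotoxicity, read by MTT assay, with a stated time of 72 h; a lower number here means a stronger inhibitor, a higher number a weaker inhibitor:
compound 1 `O=C1Nc2ccccc2/C1=N/NC(=S)NC1CCCCC1` gives 4380 nM
compound 2 `COc1ccccc1NC(=S)N/N=C1\C(=O)Nc2ccccc21` gives 2690 nM
compound 3 `COc1cc(NC(=S)N/N=C2\C(=O)Nc3ccccc32)cc(OC)c1OC` gives 3490 nM

These three values lie within the usual scatter of one another, so compound 1 holds no place apart from compound 2 or compound 3. Compound 4 (`O=C1Nc2ccccc2/C1=N/NC(=S)Nc1ccc(F)cc1`) has not yet been measured. It carries 4-fluorophenyl in place of cyclohexyl on an amide-type nitrogen and keeps the core of compound 1. For the measured compounds named here, no measured pair isolates this change. Compound 2 (2690 nM) and compound 3 (3490 nM) also bear an aromatic ring on that nitrogen, yet they stay within the scatter of compound 1 (4380 nM). In this assay only a small step is therefore expected, perhaps towards a lower number, and none beyond the scatter. The expected change is (a 1.8-fold lower number from compound 1 to compound 4 (0.24 log units; within the scatter)) by this estimate. For compound 4 the estimated value is 2500 nM with an expected range from 1000 nM to 6000 nM in this assay.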

Compound 4, half-maximal inhibitory concentration: 1920 nM
Compound 4: middle estimate off by 1.3-fold (0.11 log units), on the high side; measured number inside the range.
By their numbers in this assay, from the lowest: compounds 4, 2, 3 and 1 (each within the scatter of the next, the first and the last beyond it).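

Putting 4-fluorophenyl in place of cyclohexyl on the amide-type nitrogen gives a 2.3-fold lower number from compound 1 to compound 4 (0.36 log units; beyond the scatter) in this assay, which shows that a single change at this position can move the number beyond the scatter, though only modestly. Compound 2 at 2690 nM and compound 3 at 3490 nM also bear an aromatic ring there and stay within the scatter of compound 1 , so the step holds for 4-fluorophenyl and not for every aromatic ring shown. Nothing given here offers an explanation for the step.

On these data alone, whether the step belongs to the ring or to the fluorine stays open, and a plain phenyl group on that nitrogen would separate the two. As far as these compounds go, how an open chain such as n-hexyl, or a ring carrying an amine or a carboxylic acid, would read at this position also remains unknown.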